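Cyclohexyl to benzyl on the imidazole nitrogen of compound 1

The compounds below may be only part of what the source reports. "The series", "measured", "known", "first", "only" and "open" are said of these compounds alone.

Compound 1 `O=Cc1ccc(-c2cn3ccnc3c(-c3ccc4ncn(C5CCCCC5)c4c3)n2)cc1` is the reference point. For the measured compounds named here, in a functional assay on RPMI-8226 cells (Homo sapiens) for inhibition, read by sulforhodamine B assay, with a stated time of 48 h, tested at 10 uM (on this read-out higher numbers stand for more inhibition at the one concentration tested (going by the name of the read-out) and lower numbers for less inhibition), compound 1 gives 82.5%, the higher of the two numbers measured so far. Going by the values given here, its only measured neighbour is compound 2 `Brc1ccc(-c2cn3ccnc3c(-c3ccc4ncn(C5CCCCC5)c4c3)n2)cc1`, which in this assay gives 32.1%; the step of a number 50.4 percentage points lower from compound 1 to compound 2 (beyond the scatter) came with bromo in place of formyl on an aromatic carbon, a change at the aryl end of the shared core.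

Compound 3 `O=Cc1ccc(-c2cn3ccnc3c(-c3ccc4ncn(Cc5ccccc5)c4c3)n2)cc1` keeps the formyl group of compound 1 and differs only at the ring nitrogen: benzyl in place of cyclohexyl on an aromatic nitrogen. Among the compounds with values here, no measured step touches that position, so the large bromo-for-formyl step gives no direct guide; the aromatic nitrogen of compound 3 is simply unprobed. With no evidence either way, compound 3 is expected to stay close to compound 1 in this assay, a step of a number 4.5 percentage points lower from compound 1 to compound 3 (within the scatter) within the scatter. Compound 3 is estimated at 78%, range 55% to 92%.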

Compound 3, a percentage reported as inhibition, at one concentration (the size of the read-out at that concentration, not a potency): 82.5%
Estimate against measurement, compound 3: 4.5 percentage points below; the range from low to high includes it.
By their numbers in this assay, from the lowest: compound 2; then compounds 1 and 3 (each within the scatter of the next).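

Benzyl in place of cyclohexyl on an aromatic nitrogen came with no change at the digits printed from compound 1 to compound 3 (within the scatter) in this assay, so this is the first reading at the ring nitrogen, and with the formyl group held fixed, the swap from a non-aromatic ring to a benzyl group leaves the read-out where it was. Within these three compounds, the large step remains the one at the aryl end, a number 50.4 percentage points lower from compound 1 to compound 2 (beyond the scatter), while the step at the ring nitrogen stays within the scatter. No measurement shown here bears on why cyclohexyl and benzyl read alike.

Open, going by these compounds, is whether other groups on this nitrogen, such as methyl, a longer alkyl chain or a chain ending in an amine, would hold the read-out as well. Also open, on these data alone, is whether benzyl behaves the same with bromo in place of formyl, and a reading at one concentration cannot separate the potencies of compound 1 and compound 3.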